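From 4-hydroxyphenyl to 4-nitrophenyl: working notes

The source may hold more compounds than are shown below. What is called first, only, known or untested is meant among the compounds shown, and "the series" means these compounds.

Of the compounds shown here, two have been measured so far in a functional assay on MCF7 cells (Homo sapiens) for cytotoxicity, read by MTT assay, with a stated time of 48 h (a lower number here means a stronger inhibitor, a higher number a weaker inhibitor), and give these values.

- compound 1 `O=C1CS/C(=N/c2ccccc2)N1Cc1ccncc1` gives 65800 nM
- compound 2 `O=C1/C(=C\c2ccc(O)cc2)S/C(=N/c2ccccc2)N1Cc1ccncc1` gives 18900 nM

Compound 2 holds the lower of the two numbers, and its gap to compound 1 lies beyond the scatter. Compound 3 `O=C1/C(=C\c2ccc([N+](=O)[O-])cc2)S/C(=N/c2ccccc2)N1Cc1ccncc1` has not yet been measured. It carries nitro in place of hydroxy on an aromatic carbon, para to a large group (nitro in place of hydroxy on an aromatic carbon), so 4-hydroxyphenyl becomes 4-nitrophenyl. Among the measured compounds shown here, no measured pair shows this exchange, so the data offer no direct guide to its size. A slight move toward a lower number is expected, but none beyond the scatter. The estimated 1.3-fold lower number from compound 2 to compound 3 (0.10 log units; within the scatter) stays within that scatter. Expected for compound 3 in this assay is 15000 nM within a range of 5000 nM to 45000 nM as an estimate.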

Compound 3, half-maximal inhibitory concentration: 13000 nM
For compound 3 the middle estimate is 1.2-fold (0.06 log units) above the measured one; the measured number falls inside the stated range.
By their numbers in this assay, from the lowest: compounds 3 and 2 (each within the scatter of the next); then compound 1.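

In this assay, nitro in place of hydroxy on an aromatic carbon, para to a large group, gives a 1.5-fold lower number from compound 2 to compound 3 (0.16 log units; within the scatter), so compound 2 and compound 3 cannot be told apart. Among the compounds shown here, this pair adds what the earlier compounds could not show: at this position, the hydrogen-bond donor of hydroxy can be lost and a larger group with more hydrogen-bond acceptors can enter without a reading beyond the scatter. No measurement bears on what lies behind this result.

Going by these compounds, whether an amine, a carboxylic acid or a methoxy group at this same position would give a number beyond the scatter remains open. Also open, on these data alone, is whether a longer chain elsewhere on the shared core would shift the reading in this assay.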